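The source may hold more compounds than are shown below. What is called first, only, known or untested is meant among the compounds shown, and "the series" means these compounds.

In a functional assay on K562 cells (Homo sapiens) for cytotoxicity, read by sulforhodamine B assay (a lower number here means a stronger inhibitor of growth, a higher number a weaker inhibitor of growth), three compounds built on a shared core have been measured. Compound 1 `CC1=CC[C@@H]([C@@](C)(O)CCCC(C)(C)NC=S)CC1` gives 16700 nM, compound 2 `CC1=CC[C@@H]([C@@](C)(O)CCCC(C)(C)NC(=S)N/N=C\c2ccc(O)cc2)CC1` gives 600 nM, and compound 3 `CC1=CC[C@@H]([C@@](C)(O)CCCC(C)(C)NC(=S)N/N=C\c2cccc([N+](=O)[O-])c2)CC1` gives 20 nM. Compound 2 therefore holds the second highest of the three numbers, and its distance to each of the other two lies beyond the scatter. Compound 4 `CC1=CC[C@@H]([C@@](C)(O)CCCC(C)(C)NC(=S)N/N=C\c2cccc(Cl)c2)CC1` differs from compound 2 by one change: 3-chlorophenyl in place of 4-hydroxyphenyl on a carbon with a double bond to nitrogen. In words, 3-chlorophenyl stands in place of 4-hydroxyphenyl on a carbon with a double bond to nitrogen. Among the compounds with values here, one measured step bears on this change: a 30-fold lower number from compound 2 to compound 3 (1.48 log units; beyond the scatter), which is large and replaces the same 4-hydroxyphenyl at the same place with 3-nitrophenyl. Within the data shown here, no compound carrying chlorine has been measured, so this single step is only a rough guide to the size of the change. A lower number is therefore expected, with an estimated step of an 8.6-fold lower number from compound 2 to compound 4 (0.93 log units; beyond the scatter), somewhat smaller than the measured one. For compound 4 the expected value is 70 nM, within an estimated range from 15 nM to 350 nM.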

Compound 4, concentration for 50% growth inhibition: 30 nM
Beside the measured number, compound 4's estimate is 2.3-fold (0.37 log units) above it; measured number inside the range.
By their numbers in this assay, from the lowest: compounds 3 and 4 (each within the scatter of the next); then compound 2; then compound 1.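

In this assay the replacement of 4-hydroxyphenyl on this carbon now gives a 20-fold lower number from compound 2 to compound 4 (1.30 log units; beyond the scatter) with 3-chlorophenyl, a second large step down after a 30-fold lower number from compound 2 to compound 3 (1.48 log units; beyond the scatter) with 3-nitrophenyl. With chloro in place of nitro on an aromatic carbon the series shows a 1.5-fold higher number from compound 3 to compound 4 (0.18 log units; within the scatter) and thus no separation between the two, so the low number at this place is not tied to the nitro group. No measured evidence here explains why either replacement has this effect.

Still open, on these data alone, is whether a 4-chlorophenyl would match 3-chlorophenyl in this assay. Also open, as far as these compounds go, is whether a 3-hydroxyphenyl or a 3-aminophenyl on the same carbon would stay with compound 3 and compound 4 or return towards compound 2.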